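A few compounds are considered here, and "the series" means these few. Any claim that something is new, unique, unknown or untested is made for them only; others in the source may bear on it.

In an ADME assay on J774.1 cells (Mus musculus) for cytotoxicity, read by resazurin assay, with a stated time of 48 h (on this read-out higher numbers stand for weaker inhibition and lower numbers for stronger inhibition), compound 1 `CCCCn1cc(C(=O)O)c(=O)c2cc(F)c(Cl)cc21` gives > 100000 nM, a limit of the assay and not a number. Compound 2 `CCCCn1cc(C(=O)O)c(=O)c2cc(F)c(N3CCC(C(N)=O)CC3)cc21` gives > 100000 nM, also a limit. Compound 3 `NC(=O)C1CCN(c2cc3c(cc2F)c(=O)c(C(=O)O)cn3C2CC2)CC1` gives > 100000 nM, a limit as well. This is the limit of > 100000 nM in this assay, at which 3 of the 3 values shown sit. The measured changes are therefore a step that the two limits leave unreadable from compound 1 to compound 2 and a step that the two limits leave unreadable from compound 2 to compound 3, and neither touches the carboxy group. Compound 4 `CCCCn1cc(C(=O)NCc2ccc(OC)cc2)c(=O)c2cc(F)c(N3CCC(C(N)=O)CC3)cc21` changes exactly that group, with (4-methoxybenzyl)amino in place of hydroxy on a carbonyl carbon. For the measured compounds named here, no measured step gives a size for this change, so the estimate is only a cautious one. Expected is an at least 1.4-fold lower number from compound 2 to compound 4 (0.15 log units; that floor lies within the scatter), a modest move toward stronger inhibition that may stay unreadable. For compound 4 the estimated value is 70000 nM, with an expected range from 20000 nM to 100000 nM.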

Compound 4, half-maximal inhibitory concentration: 40800 nM
Beside the measured number, compound 4's estimate is 1.7-fold (0.23 log units) above it; low and high end bracket the measured number.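

In this assay, (4-methoxybenzyl)amino in place of hydroxy on the carbonyl carbon gives an at least 2.4-fold lower number from compound 2 to compound 4 (0.38 log units; beyond the scatter), the first readable move toward stronger inhibition in this series. The earlier steps cannot be read, and compound 4 is the only compound here with a true number rather than a limit, so the full size of this step also stays unknown: the limit of > 100000 nM in this assay, at which 3 of the 4 values shown sit.

From the compounds shown here alone, it remains open whether a plain benzylamino group, without the methoxy, or a small methylamino group on the same carbonyl carbon would lower the number as far.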